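The source may hold more compounds than are shown below. What is called first, only, known or untested is meant among the compounds shown, and "the series" means these compounds.

Measured compounds, all in a functional assay on A549 cells (Homo sapiens) for cytotoxicity, read by MTT assay, with a stated time of 72 h; a higher number here means a weaker inhibitor, a lower number a stronger inhibitor:
compound 1, `COc1ccc(OC)c(/C=N/NC(=O)Nc2ccc(Oc3ccnc(-c4nncn4CCN(C)C)c3)c(F)c2)c1`, gives 1950 nM
compound 2, `CN(C)CCn1cnnc1-c1cc(Oc2ccc(NC(=O)N/N=C/c3cccc(Br)c3)cc2F)ccn1`, gives 970 nM
compound 3, `CN(C)CCn1cnnc1-c1cc(Oc2ccc(NC(=O)N/N=C/c3ccc(F)cc3Cl)cc2F)ccn1`, gives 1120 nM

Compound 3 has the second highest of the three numbers in this assay; its nearest neighbour is compound 2 and its furthest is compound 1, and both gaps lie within the scatter. Compound 4, `CN(C)CCn1cnnc1-c1cc(Oc2ccc(NC(=O)N/N=C/c3ccc(Cl)cc3)cc2F)ccn1`, is not yet measured. It differs from compound 3 in one place: 4-chlorophenyl in place of 2-chloro-4-fluorophenyl on a carbon with a double bond to nitrogen.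

Every measured step in this series changes the aryl on that same carbon, and none leaves the scatter: a 2.0-fold lower number from compound 1 to compound 2 (0.30 log units; within the scatter), a 1.7-fold lower number from compound 1 to compound 3 (0.24 log units; within the scatter), a 1.2-fold higher number from compound 2 to compound 3 (0.06 log units; within the scatter). Three aryl groups of differing substitution give indistinguishable numbers, so for compound 4 the step of a 1.1-fold lower number from compound 3 to compound 4 (0.05 log units; within the scatter) is expected to stay within the scatter too. Compound 4 is estimated at 1000 nM, with a range of 500 nM to 2200 nM.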

Compound 4, half-maximal inhibitory concentration: 780 nM
For compound 4 the middle estimate is 1.3-fold (0.11 log units) above the measured one; low and high end bracket the measured number.
By their numbers in this assay, from the lowest: compounds 4, 2, 3 and 1 (each within the scatter of the next, the first and the last beyond it).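

Going by these compounds alone, at the aryl on the carbon with a double bond to nitrogen, 4-chlorophenyl gives the only measured step in this assay that lies beyond the scatter, a modest one against 2,5-dimethoxyphenyl (a 2.5-fold lower number from compound 1 to compound 4 (0.40 log units; beyond the scatter)). Against the other halogen-bearing aryls it stays inside the scatter (a 1.4-fold lower number from compound 3 to compound 4 (0.16 log units; within the scatter); a 1.2-fold lower number from compound 2 to compound 4 (0.09 log units; within the scatter)), so these three cannot be ordered. Nothing available accounts for the gap to compound 1.

Open, going by these compounds, is whether one methoxy group alone would keep compound 1's number. Also open, on these data alone, is how a nitrile or a carboxylic acid on this aryl would compare.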